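A few compounds are considered here, and "the series" means these few. Any claim that something is new, unique, unknown or untested is made for them only; others in the source may bear on it.

Measured compounds:
Compound 1 `CCc1ccccc1-c1cc(C(=O)N[C@@H](CCN2CCCCC2)CC(=O)NC2CCC2)nn1C1CCCC1` — an ADME assay on microsomes from liver (Rattus norvegicus, strain Sprague-Dawley) for metabolic stability, read by LC-MS, using NADPH, with a stated time of 30 min, tested at 1 uM; on this read-out lower numbers stand for a less stable compound and higher numbers for a more stable compound: 76.5%
Compound 2 `O=C(C[C@H](CCN1CCCCC1)NC(=O)c1cc(-c2ccccc2Cl)n(C2CCCC2)n1)NC1CCC1` — this assay: "nd" (no result reported)
Compound 3 `Cc1noc(C)c1-c1cc(C(=O)N[C@@H](CCN2CCCCC2)CC(=O)NC2CCC2)nn1C1CCCC1` — this assay: "nd" (no result reported)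

Compound 2 carries a 2-chlorophenyl group on the shared core. In this assay compound 2 has no number: no result was reported for it, and the same holds for compound 3. Within the data shown here, only compound 1 gives a value, 76.5%, and no step between two measured compounds is available.

Compound 4 `O=C(C[C@H](CCN1CCCCC1)NC(=O)c1cc(-c2ccccc2C2CC2)n(C2CCCC2)n1)NC1CCC1` differs from compound 2 in one place: cyclopropyl in place of chloro on an aromatic carbon

Among the measured compounds shown here, with no measured step to rest on, no direction for the change from compound 2 to compound 4 can be read from the data. For the measured compounds named here, the single value of compound 1, 76.5%, is the only anchor. Compound 4 is therefore expected to come out near 68%, in a range from 40% to 90%.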

Compound 4, percent of the compound remaining: 70.1%
For compound 4 the middle estimate is 2.1 percentage points below the measured one; the range from low to high includes it.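

Among these compounds, compound 4 gives a reading for a cyclopropyl group at this place, on an aromatic carbon ortho to a large group, and so adds a second number to the single value of compound 1. In this assay there is a number 6.4 percentage points lower from compound 1 to compound 4 (within the scatter), so cyclopropyl in place of ethyl here cannot be told apart from ethyl. No measured finding offers an explanation for this result.

The step from compound 2 to compound 4 cannot be read, as compound 2 has no reported result. On these data alone, how a methoxy group or a carboxylic acid at this place would read remains open.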